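Taking the hydroxy out of the compound 3 chain

The compounds below may be only part of what the source reports. "The series", "measured", "known", "first", "only" and "open" are said of these compounds alone.

Three compounds sharing one core, and differing in the chain on sulfur, have been measured in a functional assay on HT cells (Homo sapiens) for antiproliferative activity, read by fluorescence, with a stated time of 72 h; a higher number here means a weaker inhibitor of growth, a lower number a stronger inhibitor of growth. Compound 1 (`CC(C)c1n[nH]c2c(NCc3ccc(-c4ccccn4)cc3)nc(SCC(O)CN3CCNCC3)nc12`) gives 332 nM, compound 2 (`CC(C)c1n[nH]c2c(NCc3ccc(-c4ccccn4)cc3)nc(SCCC(N)=O)nc12`) gives 120 nM, and compound 3 (`CC(C)c1n[nH]c2c(NCc3ccc(-c4ccccn4)cc3)nc(SC[C@H](O)CN)nc12`) gives 63 nM. Compound 3 stands clear of one neighbour, with a 5.3-fold lower number from compound 1 to compound 3 (0.72 log units; beyond the scatter), but not of the other, with a 1.9-fold lower number from compound 2 to compound 3 (0.28 log units; within the scatter).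

Compound 4 (`CC(C)c1n[nH]c2c(NCc3ccc(-c4ccccn4)cc3)nc(SCCCN)nc12`) is compound 3 with a single change: hydrogen in place of hydroxy on a saturated chain carbon bound to two saturated chain carbons. Hydrogen takes the place of hydroxy on a saturated chain carbon bound to two saturated chain carbons, so 3-amino-2-hydroxypropyl becomes 3-aminopropyl.

Among the compounds with values here, no measured pair isolates this hydroxy, so the evidence is indirect. The chains of compound 1 and compound 3 both carry a hydroxy, and a 5.3-fold lower number from compound 1 to compound 3 (0.72 log units; beyond the scatter) shows that its presence alone does not fix the number. The chain of compound 2 carries carbamoylmethyl and no hydroxy, yet a 1.9-fold lower number from compound 2 to compound 3 (0.28 log units; within the scatter) leaves it level with compound 3. The remaining step, a 2.8-fold lower number from compound 1 to compound 2 (0.44 log units; beyond the scatter), also replaces the piperazine-bearing chain and is modest. On this basis, no change beyond the scatter is expected in this assay, in either direction. The expected step is a 1.2-fold higher number from compound 3 to compound 4 (0.08 log units; within the scatter). For compound 4 the estimate is 75 nM, with an expected range from 30 nM to 190 nM.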

Compound 4, concentration for 50% growth inhibition: 120 nM
Compound 4: middle estimate off by 1.6-fold (0.20 log units), on the low side, and the stated range covers the measured number.
By their numbers in this assay, from the lowest: compounds 3, 2 and 4 (each within the scatter of the next); then compound 1.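

In this assay this position now has a direct reading (a 1.9-fold higher number from compound 3 to compound 4 (0.28 log units; within the scatter)): on the saturated chain carbon bound to two saturated chain carbons, hydrogen can stand in place of hydroxy with no change that can be told from the scatter, so 3-aminopropyl stays level with 3-amino-2-hydroxypropyl. The new compound also gives a second chain comparison, with aminomethyl in place of carbamoyl (no change at the digits printed from compound 2 to compound 4 (within the scatter)), while the step from the piperazine-bearing chain (a 2.8-fold lower number from compound 1 to compound 4 (0.44 log units; beyond the scatter)) is the only one of the three new steps beyond the scatter. Nothing available here accounts for any of these numbers.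

Going by these compounds, whether a methoxy group or a fluorine atom on that saturated chain carbon would also stay level with hydroxy and hydrogen remains open. On these data alone, it is also open whether a longer chain, or a carboxylic acid in place of the amine of 3-aminopropyl, would hold the number near those of compound 3 and compound 4 in this assay or move it beyond the scatter.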